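The compounds below may be only part of what the source reports. "The series", "measured", "known", "first", "only" and "open" are said of these compounds alone.

Compound 1 `Cc1ccc(-c2ccc(C)n2-c2ccc(-c3nc4ccc(F)cc4s3)cc2)cc1` and compound 2 `Cc1ccc(-c2ccc(F)cc2)n1-c1ccc(-c2nc3ccc(F)cc3s2)cc1` share one core, while compound 3 `COc1cc2nc(-c3ccc(-n4c(C)ccc4-c4ccc(C)cc4)cc3)sc2c(OC)c1OC` is built on another; the difference between the two cores is not broken down here. In a functional assay on MDA-MB-231 cells (Homo sapiens) for cytotoxicity, read by MTT assay, with a stated time of 72 h (on this read-out higher numbers stand for weaker inhibition and lower numbers for stronger inhibition), compound 1 gives 16700 nM, and in this assay compound 2 gives 14100 nM. The change between them, (fluoro in place of methyl on an aromatic carbon), made a 1.2-fold lower number from compound 1 to compound 2 (0.07 log units; within the scatter). In this assay compound 3 gives 12300 nM, a number that sits within the scatter of both compound 1 and compound 2. Compound 4 `COc1cc2nc(-c3ccc(-n4c(C)ccc4-c4ccc(F)cc4)cc3)sc2c(OC)c1OC` has not yet been measured in this assay. It differs from compound 3 by fluoro in place of methyl on an aromatic carbon, the same change that leads from compound 1 to compound 2, at the same kind of place. Since that earlier step lay within the scatter, compound 4 is expected to stay close to compound 3, with an estimated 1.1-fold lower number from compound 3 to compound 4 (0.05 log units; within the scatter) beside the earlier 1.2-fold lower number from compound 1 to compound 2 (0.07 log units; within the scatter). Compound 4 is therefore estimated in this assay at 11000 nM, with a range from 5500 nM to 22000 nM, resting on the value of compound 3 of 12300 nM.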

Compound 4, half-maximal inhibitory concentration: 13100 nM
Compound 4: middle estimate off by 1.2-fold (0.08 log units), on the low side; the range from low to high includes it.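

In this assay the change from 4-methylphenyl to 4-fluorophenyl on the core of compound 3 gave a 1.1-fold higher number from compound 3 to compound 4 (0.03 log units; within the scatter) and so, as on the core of compound 1, left the number within the scatter. Set side by side, the two steps do not differ: the same change on two cores in this assay, a 1.2-fold lower number (0.07 log units; within the scatter) from compound 1 to compound 2 and a 1.1-fold higher number (0.03 log units; within the scatter) from compound 3 to compound 4, 1.3-fold (0.10 log units) apart, within the scatter of two such steps. Among these compounds, this shows that on these two cores the change behaves alike, as a step too small to read, but it does not show that the change carries a measurable effect from one core to the other, as neither step stands clear of the scatter and only two cores are compared.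

The compounds shown leave open whether a different group at the same place on the six-membered aromatic ring, such as an amine, a carboxylic acid or a nitrile, would move the number beyond the scatter on either core. They also leave open whether the step from methyl to fluoro would stay this small on any further core.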